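A few compounds are considered here, and "the series" means these few. Any claim that something is new, unique, unknown or untested is made for them only; others in the source may bear on it.

Compounds measured so far:
Compound 1 `C#CCSc1nnc(CC)n1N1C(=O)c2ccccc2C1=O`: in a functional assay on HepG2 cells (Homo sapiens) for cytotoxicity, read by MTT assay, with a stated time of 48 h (a higher number here means a weaker inhibitor, a lower number a stronger inhibitor), compound 1 gives only a limit, > 200000 nM.
Compound 2 `CCCc1nnc(SCC(=O)c2ccc(Cl)cc2)n1N1C(=O)c2ccccc2C1=O`: in this assay compound 2 likewise gives only a limit, > 200000 nM.

Compound 2 therefore stands nowhere in particular on the numbers shown: both values are limits rather than numbers, and the limit of > 200000 nM in this assay, at which 2 of the 2 values shown sit, holds for every value in this assay. Going by the values given here, no step between measured compounds can be read, and compound 2 can be ranked neither above nor below compound 1.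

Compound 3 `C#CCSc1nnc(CCC)n1N1C(=O)c2ccccc2C1=O` differs from compound 2 by ethynyl in place of (4-chlorophenyl)carbonyl on a saturated chain carbon bound to a sulfur. Among the compounds with values here, since compound 1 also gives only a limit in this assay, nothing among the measured compounds points to a number below the limit. The step from compound 2 to compound 3 is expected to be none beyond the scatter, a step that the limit leaves unreadable from compound 2 to compound 3. Compound 3 is expected to give 300000 nM in this assay, between 100000 nM and 1000000 nM, most likely again reported only as a limit.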

Compound 3, half-maximal inhibitory concentration: > 200000 nM
Compound 3: only a limit was reported (the forecaster's own chance of this, stated with the estimate: 85%); the middle value lies beyond the limit too.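

In this assay compound 3 gives > 200000 nM, which is a limit and not a number. The steps to compound 3 from compound 1 and compound 2 therefore cannot be read. The compounds shown leave open whether any change on the shared core would give a measurable value: the limit of > 200000 nM in this assay, at which 3 of the 3 values shown sit.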